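Cytotoxicity notes: phenyl against pyridin-4-yl analogues

The source may report more compounds than this note shows. Statements on the series, on what has been measured and on what is new or still open speak of the compounds shown alone.

Three compounds have been read in an ADME assay on Vero cells (Chlorocebus sabaeus) for cytotoxicity, read by MTT assay, with a stated time of 72 h; on this read-out higher numbers stand for lower toxicity in this test and lower numbers for higher toxicity in this test:
- compound 1 `CC1CC(C)(C)CC(O)(c2nnc(-c3ccccc3)[nH]2)C1`: 383 ug/mL
- compound 2 `CC1CC(C)(C)CC(O)(c2nnc(-c3ccncc3)[nH]2)C1`: 414 ug/mL
- compound 3 `OC1CCC(C(O)c2nnc(-c3ccccc3)[nH]2)CC1O`: 429 ug/mL

Within the core of compound 1, the change pyridin-4-yl in place of phenyl on an aromatic carbon gives a 1.1-fold higher number from compound 1 to compound 2 (0.03 log units; within the scatter). Compound 3 carries a different core; the difference between the two cores is not broken down here. The values of compound 3, compound 2 and compound 1 in this assay all sit within the scatter of one another, so no order among them can be read.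

Compound 4 `OC1CCC(C(O)c2nnc(-c3ccncc3)[nH]2)CC1O` is not yet measured. It relates to compound 3 as compound 2 relates to compound 1: pyridin-4-yl in place of phenyl on an aromatic carbon, the same change at the same place. Among the measured compounds shown here, the expected step of a 1.0-fold higher number from compound 3 to compound 4 (0.02 log units; within the scatter) is set beside the earlier one because a 1.1-fold higher number from compound 1 to compound 2 (0.03 log units; within the scatter) stayed within the scatter, and nothing among the measured compounds suggests the second core should answer differently. Compound 4 is therefore expected to give about 450 ug/mL in this assay, most likely between 300 ug/mL and 700 ug/mL.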

Compound 4, half-maximal cytotoxic concentration: 429 ug/mL
Compound 4: middle estimate off by 1.0-fold (0.02 log units), on the high side; the range from low to high includes it.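

In this assay, pyridin-4-yl in place of phenyl on the core of compound 3 gives no change at the digits printed from compound 3 to compound 4 (within the scatter). Set beside the earlier step, the same change reads alike on the two cores: the same change on two cores in this assay, a 1.1-fold higher number (0.03 log units; within the scatter) from compound 1 to compound 2 and no change at the digits printed (within the scatter) from compound 3 to compound 4, 1.1-fold (0.03 log units) apart, within the scatter of two such steps

Among the compounds shown here, this shows only that on these two cores the swap stays within the scatter in this test; two pairs do not establish a rule for other cores, and with both steps within the scatter there is no measurable effect whose size could be said to carry over. The result also says nothing about any other test.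

The compounds shown leave open whether an amine or a carboxylic acid in place of the phenyl on that aromatic carbon would give a step beyond the scatter. They also leave open how the same change would read on a core carrying a longer chain in place of the hydroxyl groups.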